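Adding a tert-butylamino group to the acyl chain of compound 3

The source may hold more compounds than are shown below. What is called first, only, known or untested is meant among the compounds shown, and "the series" means these compounds.

Three pyrazoline-type compounds were tested in a functional assay on MGC-803 cells (Homo sapiens) for cytotoxicity, read by MTT assay, with a stated time of 48 h; a higher number here means a weaker inhibitor, a lower number a stronger inhibitor. Compound 1 `CC1=NN(C(=O)COc2ccc(Cl)cc2)C(c2cc(Br)cc(Br)c2O)C1` gives 50000 nM, compound 2 `COc1ccccc1C1CC(C)=NN1C(=O)C[N+]1(C)CCCC1` gives 12200 nM, and compound 3 `CCC(=O)N1N=C(c2cc3ccccc3oc2=O)CC1c1ccccc1` gives 5300 nM, the lowest of the three and beyond the scatter from each of the others, so compound 3 is the strongest inhibitor among them. Compound 4 `CC(C)(C)NCC(=O)N1N=C(c2cc3ccccc3oc2=O)CC1c1ccccc1` differs from compound 3 in one place: (tert-butyl)amino in place of methyl on a saturated chain carbon bound to a carbonyl carbon. Among the compounds with values here, no step between measured compounds covers such a change, so the direction cannot be read from these data; the step from compound 3 to compound 4 in this assay is expected to be small, plausibly within the scatter, a 1.2-fold lower number from compound 3 to compound 4 (0.07 log units; within the scatter). Compound 4 is therefore estimated at 4500 nM, in a range from 1500 nM to 13000 nM.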

Compound 4, half-maximal inhibitory concentration: 15400 nM
For compound 4 the middle estimate is 3.4-fold (0.53 log units) below the measured one, and the stated range ends below it.
By their numbers in this assay, from the lowest: compound 3; then compounds 2 and 4 (each within the scatter of the next); then compound 1.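

In this assay, the change shows a 2.9-fold higher number from compound 3 to compound 4 (0.46 log units; beyond the scatter) when (tert-butyl)amino replaces methyl on the saturated chain carbon bound to a carbonyl carbon. This position is therefore not indifferent to substitution, and this larger amine gives a modest loss of potency rather than a gain. No measured evidence here accounts for the shift. The compounds shown leave open whether the nitrogen or the tert-butyl group drives this step, and how a smaller amine such as methylamino, a pyrrolidine or a carboxylic acid would behave at this place.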